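Trimming the Side Chain of a Hydroxamate Sulfonamide

The compounds below may be only part of what the source reports. "The series", "measured", "known", "first", "only" and "open" are said of these compounds alone.

Of the compounds shown here, three have been measured so far. Compound 1 `O=C(NO)c1cccc(S(=O)(=O)Nc2ccccc2)c1` gives 50 nM in an assay on isolated protein for inhibition of histone deacetylase 8 (Homo sapiens), read by fluorescence, with stated times of 5 min and 30 min; a lower number here means a stronger inhibitor, a higher number a weaker inhibitor. Compound 2 `CC(C)[C@H](NS(=O)(=O)c1cccc(C(=O)NO)c1)C(=O)Nc1ccccc1` gives 33900 nM, and compound 3 `O=C(NO)c1cccc(S(=O)(=O)N[C@H](C(=O)Nc2ccccc2)c2ccccc2)c1` gives 910 nM, which places compound 3 second highest of the three numbers. Within the data shown here, the only counted step, a 37-fold lower number from compound 2 to compound 3 (1.57 log units; beyond the scatter), shows that the group on the chain carbon next to the sulfonamide matters greatly. Compound 4 `O=C(NO)c1cccc(S(=O)(=O)NCc2ccccc2)c1` carries hydrogen in place of phenylcarbamoyl on a saturated chain carbon bound to an aromatic carbon and a sulfonamide nitrogen, leaving only a benzyl group on the sulfonamide nitrogen, which brings it close in shape to compound 1. Among the measured compounds shown here, no measured step covers removal of this group, but the two values of compound 1 and compound 3 suggest the smaller compounds fare well here. Compound 4 is therefore expected to give 150 nM, within 40 nM to 600 nM, a step of a 6.1-fold lower number from compound 3 to compound 4 (0.78 log units; beyond the scatter) that is expected toward a lower number.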

Compound 4, half-maximal inhibitory concentration: 80 nM
Estimate against measurement, compound 4: 1.9-fold (0.27 log units) above; the measured number falls inside the stated range.
By their numbers in this assay, from the lowest: compounds 1 and 4 (each within the scatter of the next); then compound 3; then compound 2.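

Hydrogen in place of phenylcarbamoyl on the saturated chain carbon gives a large change, (an 11-fold lower number from compound 3 to compound 4 (1.06 log units; beyond the scatter)), so in this series the phenylcarbamoyl group goes with a weaker inhibitor, not a stronger one. Benzyl in place of phenyl on the sulfonamide nitrogen gives (a 1.6-fold higher number from compound 1 to compound 4 (0.20 log units; within the scatter)), which lies within the scatter, so compound 1 and compound 4 cannot be told apart. No measured evidence explains either step.

From the compounds shown here alone, whether a methyl group or a carboxylic acid on that chain carbon would match hydrogen remains open. So does the effect of a longer chain, such as phenethyl, on the sulfonamide nitrogen.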